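The source may report more compounds than this note shows. Statements on the series, on what has been measured and on what is new or still open speak of the compounds shown alone.

Measured compounds in a functional assay on HepG2 cells (Homo sapiens) for inhibition, read by MTT assay, with a stated time of 72 h; on this read-out higher numbers stand for weaker inhibition and lower numbers for stronger inhibition:

Compound 1 `O=C(Nc1ccc(Oc2ccnc3[nH]ccc23)cc1)c1cn(-c2ccc(F)cc2)c2ccccc2c1=O` gives 450 nM
Compound 2 `O=C(Nc1ccc(Oc2ccnc3[nH]ccc23)cc1)c1cn(-c2ccc(Cl)cc2)c2ccccc2c1=O` gives 250 nM
Compound 3 `Cn1ccc2c(Oc3ccc(NC(=O)c4cn(-c5ccc(Cl)cc5)c5ccccc5c4=O)cc3F)ccnc21` gives 290 nM

Among these three, compound 3 stands in the middle on paper, but its gaps to the others are small: compared with compound 2 the number is nearly the same, and compared with compound 1 the difference is also within the scatter, so no ordering can be read from these values.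

Compound 4 `COc1ccc(-n2cc(C(=O)Nc3ccc(Oc4ccnc5c4ccn5C)c(F)c3)c(=O)c3ccccc32)cc1` is the unmeasured partner of compound 3. The single difference is methoxy in place of chloro on an aromatic carbon, which the data also describe as 4-chlorophenyl to 4-methoxyphenyl, at a place para to a large group.

Within the data shown here, only one measured step touches the same spot: a 1.8-fold lower number from compound 1 to compound 2 (0.26 log units; within the scatter). That step, chloro in place of fluoro on an aromatic carbon, stayed within the scatter, which suggests this position is not very sensitive to small changes in this assay. Among the measured compounds shown here, there is no measured example of a methoxy group here, so the expectation carries real uncertainty.

Compound 4 is therefore expected to lie close to compound 3, with the step of a 1.3-fold higher number from compound 3 to compound 4 (0.12 log units; within the scatter) and an estimate of 380 nM, ranging from 130 nM to 1100 nM.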

Compound 4, half-maximal inhibitory concentration: 3750 nM
Beside the measured number, compound 4's estimate is 9.9-fold (0.99 log units) below it; measured number above the stated range.
By their numbers in this assay, from the lowest: compounds 2, 3 and 1 (each within the scatter of the next); then compound 4.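

In this assay, replacing the 4-chlorophenyl with a 4-methoxyphenyl gives a 13-fold higher number from compound 3 to compound 4 (1.11 log units; beyond the scatter), a large step beyond the scatter, so inhibition is clearly weaker with methoxy. This position is therefore more sensitive than the halogen swap alone suggested: a 1.8-fold lower number from compound 1 to compound 2 (0.26 log units; within the scatter) stayed within the scatter, although that step was measured on a slightly different core. Nothing available here explains why methoxy has this effect.

From the compounds shown here alone, it remains open whether this sensitivity is specific to methoxy, or what a hydroxyl, an amine or a methyl at the same place would give. Also open, going by these compounds, is whether the same swap from chloro to methoxy would produce a step of similar size on the core of compound 2.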